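This account rests on a few compounds, and the source may have more. Where it says the series, first, only, none or still open, it means among the compounds named here.

Measured compounds in a functional assay on IGROV-1 cells (Homo sapiens) for inhibition; on this read-out higher numbers stand for weaker inhibition and lower numbers for stronger inhibition:
compound 1, `O=C(O)CC1CC(CNC(=O)CCCNc2ccccn2)=CCc2ccccc21`: 2 nM
compound 2, `O=C(O)CC1CC(CNC(=O)CCCNC2=NCCN2)=CCc2ccccc21`: 18 nM

For the measured compounds named here, compound 2 holds the higher of the two numbers; its only neighbour is compound 1, and the gap is a 9.0-fold higher number from compound 1 to compound 2 (0.95 log units; beyond the scatter).

Compound 3, `O=C(O)CC1CC(CNC(=O)CCCNC2=NCCCN2)=CCc2ccccc21`, differs from compound 2 by a group of 6 heavy atoms (4 carbon, 2 nitrogen; one six-membered non-aromatic ring with 2 hetero atoms) in place of a group of 5 heavy atoms (3 carbon, 2 nitrogen; one five-membered non-aromatic ring with 2 hetero atoms), on an amine nitrogen. Going by the values given here, no measured step covers this change. Among the compounds with values here, the single known step, a 9.0-fold higher number from compound 1 to compound 2 (0.95 log units; beyond the scatter), exchanges the six-membered aromatic ring for the five-membered non-aromatic ring and so speaks to a different exchange; it only shows that the group on this amine nitrogen matters. Between compound 2 and compound 3 the ring stays non-aromatic with two hetero atoms and keeps its double bond outside aromatic rings, so the step from compound 2 to compound 3 in this assay is expected to be small, a 1.2-fold lower number from compound 2 to compound 3 (0.08 log units; within the scatter), with no clear direction beyond the scatter. Compound 3 is therefore estimated at 15 nM, within a range of 5 nM to 50 nM.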

Compound 3, half-maximal inhibitory concentration: 2.7 nM
The estimate for compound 3 lay 5.6-fold (0.74 log units) above the measured number, and the stated range ends above it.
By their numbers in this assay, from the lowest: compounds 1 and 3 (each within the scatter of the next); then compound 2.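

In this assay, ring size on the amine nitrogen counts even when the ring stays non-aromatic: the six-membered non-aromatic ring with 2 hetero atoms replacing the five-membered one gives a 6.7-fold lower number from compound 2 to compound 3 (0.82 log units; beyond the scatter), although the two groups match in hydrogen-bond donors, hydrogen-bond acceptors and net charge. An aromatic ring is also not needed at this position, since the six-membered aromatic ring with 1 hetero atom and the six-membered non-aromatic ring with 2 hetero atoms stay within the scatter, with a 1.4-fold higher number from compound 1 to compound 3 (0.13 log units; within the scatter), so the weaker number of compound 2 goes with its five-membered ring in this small set. No supporting measurement on hand accounts for the ring-size step.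

Going by these compounds, whether a seven-membered ring or an open-chain guanidine on this amine nitrogen would hold the number remains open. The compounds shown also leave open how a shorter or longer chain to the amide carbonyl would act with the six-membered rings.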